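This account rests on a few compounds, and the source may have more. Where it says the series, first, only, none or still open, it means among the compounds named here.

Three compounds share one core and differ only in the group carried on an aromatic nitrogen. Compound 1 `O=C(Nc1ccc(Oc2ccnc3[nH]ccc23)c(F)c1)c1nn(-c2ccc(Br)cc2)ccc1=O` is measured in a functional assay on A549 cells (Homo sapiens) for cytotoxicity, read by MTT assay, with a stated time of 72 h (a lower number here means a stronger inhibitor, a higher number a weaker inhibitor), only as a limit of the assay, > 60000 nM, (the limit of > 60000 nM in this assay, at which 1 of the 3 values shown sits). Compound 2 `O=C(Nc1ccc(Oc2ccnc3[nH]ccc23)c(F)c1)c1nn(-c2ccccc2)ccc1=O` gives 56800 nM, which is the highest of the two numbers reported. Compound 3 `O=C(Nc1ccc(Oc2ccnc3[nH]ccc23)c(F)c1)c1nn(-c2ccc(Cl)c(F)c2)ccc1=O` gives 10300 nM. The measured steps are an at least 1.0-fold lower number from compound 1 to compound 2 (0.02 log units; that floor lies within the scatter), an at least 5.8-fold lower number from compound 1 to compound 3 (0.76 log units; beyond the scatter) and a 5.5-fold lower number from compound 2 to compound 3 (0.74 log units; beyond the scatter); all of them concern the aryl group on that aromatic nitrogen.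

Compound 4 `Cn1ccc2c(Oc3ccc(NC(=O)c4nn(-c5ccccc5)ccc4=O)cc3F)ccnc21` differs from compound 2 elsewhere: methyl in place of hydrogen on an aromatic nitrogen. Going by the values given here, no measured step touches that place, so the three steps above give no guidance on its direction or size. In the absence of any such step, a change of no more than the scatter is expected, a 1.0-fold lower number from compound 2 to compound 4 (0.01 log units; within the scatter). For compound 4 a value of 55000 nM is estimated, within a range from 18000 nM to 160000 nM.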

Compound 4, half-maximal inhibitory concentration: > 60000 nM
Compound 4 was reported as a limit; the forecaster's own chance of this, stated with the estimate: 35%; at least 1.0-fold (0.03 log units) between middle value and limit.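

Going by these compounds alone, this is the first change at the aromatic nitrogen of the five-membered ring, a position the aryl steps left untouched. Compound 4 stands only as a limit in this assay, > 60000 nM: the limit of > 60000 nM in this assay, at which 2 of the 4 values shown sit. The change therefore reads as an at least 1.0-fold higher number from compound 2 to compound 4 (0.02 log units; that floor lies within the scatter), a floor and not a measured size, so methyl in place of hydrogen here shows no stronger inhibition, while any real weakening remains unsized.

The compounds shown leave open whether a longer chain such as propyl, or a chain ending in an amine, would behave as methyl does on this nitrogen. They also leave open what methyl would do on compound 3, whose 10300 nM is a number and not a limit, so that a change in either direction could be read.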